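Oxan-4-yl in place of pyridin-2-yl on the carbonyl

A few compounds are considered here, and "the series" means these few. Any claim that something is new, unique, unknown or untested is made for them only; others in the source may bear on it.

In a physicochemical assay for lipophilicity, read by HPLC, measured as chromatographic lipophilicity, at pH 7.4 (a lower number here means a more polar compound, a higher number a more lipophilic compound), compound 3 (`O=C(c1ccccn1)N1N=CCC1c1ccccc1`) reads 2.4 and compound 1 (`O=C(c1cccnc1)N1N=CCC1c1ccccc1`) reads 2.7, the two being level within the scatter (a number 0.30 log units lower from compound 1 to compound 3 (within the scatter)). Compound 2 (`CC(C)(CN)C(=O)N1N=CCC1c1ccccc1`) stands apart from both at 1.4 in the same read-out (a number 1.00 log units higher from compound 2 to compound 3 (beyond the scatter)). Compound 4 (`O=C(C1CCOCC1)N1N=CCC1c1ccccc1`) carries oxan-4-yl in place of pyridin-2-yl on a carbonyl carbon. The nearest guide is a ring-for-ring swap (a number 0.30 log units lower from compound 1 to compound 3 (within the scatter)), which stayed small. The move to 1-(aminomethyl)-1-methylethyl (a number 1.30 log units lower from compound 1 to compound 2 (beyond the scatter)) was large but is a different kind of change. No step beyond the scatter is therefore expected (a number 0.10 log units lower from compound 3 to compound 4 (within the scatter)). Compound 4 is estimated at 2.3 with 1.8 to 2.7 as its expected range.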

Compound 4, distribution coefficient: 3.1
For compound 4 the middle estimate is 0.80 log units below the measured one, and the stated range ends below it.
By their numbers in this assay, from the lowest: compound 2; then compounds 3 and 1 (each within the scatter of the next); then compound 4.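

In (this assay), oxan-4-yl for pyridin-2-yl on the carbonyl carbon gives a step beyond the scatter (a number 0.70 log units higher from compound 3 to compound 4 (beyond the scatter)), although the two groups match in heavy atoms, donors and acceptors as counted, and the earlier swap between pyridine rings stayed within it. Oxan-4-yl also clears pyridin-3-yl (a number 0.40 log units higher from compound 1 to compound 4 (beyond the scatter)) and 1-(aminomethyl)-1-methylethyl (a number 1.70 log units higher from compound 2 to compound 4 (beyond the scatter)), leaving compound 4 highest of the four. No supporting measurement accounts for this rise.

On these data alone, whether cyclohexyl or piperidin-4-yl on the same carbonyl carbon would read like oxan-4-yl remains open. So does whether the step holds on another core.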